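Chloro in place of fluoro: compound 2 to compound 3

This account rests on a few compounds, and the source may have more. Where it says the series, first, only, none or still open, it means among the compounds named here.

Measured in a functional assay on HFF cells (Homo sapiens) for cytotoxicity; on this read-out higher numbers stand for weaker inhibition and lower numbers for stronger inhibition:
- compound 1 `N#Cc1ccc(/C=C2\SC(=S)N(NS(=O)(=O)c3ccccc3)C2=O)cc1`: > 100000 nM (a limit)
- compound 2 `O=C1/C(=C/c2ccc(Cl)c(F)c2)SC(=S)N1NS(=O)(=O)c1ccccc1`: > 100000 nM (a limit)

Compound 2 has no number to stand on: in this assay compound 2 gives > 100000 nM, which is a limit. Compound 1 gives > 100000 nM, also a limit. The whole evidence so far is the limit of > 100000 nM in this assay, at which 2 of the 2 values shown sit.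

Compound 3 `O=C1/C(=C/c2ccc(Cl)c(Cl)c2)SC(=S)N1NS(=O)(=O)c1ccccc1` follows from compound 2 by chloro in place of fluoro on an aromatic carbon, ortho to a chloro group and meta to a large group. Among the measured compounds shown here, the only measured step bearing on this ring is a step that the two limits leave unreadable from compound 1 to compound 2, and it offers no size to carry over. No shift beyond the scatter is therefore expected, and another limit is the likeliest report. The expected step is a number no higher from compound 2 to compound 3 (the limit leaves the size open). The estimate for compound 3 is 100000 nM, with an expected range of 40000 nM to 200000 nM.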

Compound 3, half-maximal inhibitory concentration: > 100000 nM
Compound 3 gave a limit, no number (the forecaster's own chance of this, stated with the estimate: 70%); the middle value lies on the limit itself.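

No step among compound 1, compound 2 and compound 3 can be read in this assay, because each gives only a limit: the limit of > 100000 nM in this assay, at which 3 of the 3 values shown sit.

Left open is how 4-cyanophenyl, 4-chloro-3-fluorophenyl and 3,4-dichlorophenyl compare in this assay, as none of the three compounds has a measured number there.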